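Swapping Fluoro for Bromo on a Fused Ring

A few compounds are considered here, and "the series" means these few. Any claim that something is new, unique, unknown or untested is made for them only; others in the source may bear on it.

In an ADME assay on microsomes from liver (Mus musculus, strain NMRI) for metabolic stability, tested at 2.5 uM (on this read-out lower numbers stand for slow clearance and higher numbers for fast clearance), compound 1 `Fc1ccc(-c2ccc(Cn3nnc4ccccc43)cc2)c(F)c1` gives 2.3 mL/min/g. Compound 2 `Fc1ccc(-c2ccc(Cn3nnc4ccccc43)cc2)c(Cl)c1` gives 1.5 mL/min/g in this assay. For the measured compounds named here, the only single-point change measured so far is a 1.5-fold lower number from compound 1 to compound 2 (0.19 log units; within the scatter). Compound 3 `Fc1cc(Cl)ccc1-c1ccc(Cn2nnc3c(F)cccc32)cn1` gives 2.2 mL/min/g in this assay; it stands second highest of the three numbers, but its gaps to compound 1 and to compound 2 are both within the scatter, so the three compounds cannot be told apart on clearance.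

Compound 4 `Fc1cc(Cl)ccc1-c1ccc(Cn2nnc3c(Br)cccc32)cn1` differs from compound 3 in one place: bromo in place of fluoro on an aromatic carbon. The measured step from compound 1 to compound 2 also exchanged one halogen for another on an aromatic carbon and stayed within the scatter, though it sat on a different ring and brought in chloro rather than bromo. Going by the values given here, no measured step speaks directly to bromo on the fused ring. Because a 1.5-fold lower number from compound 1 to compound 2 (0.19 log units; within the scatter) stayed within the scatter, compound 4 is expected to move by only a 1.1-fold higher number from compound 3 to compound 4 (0.04 log units; within the scatter), with no direction beyond the scatter. Compound 4 is therefore estimated at 2.4 mL/min/g in this assay, with a range from 1.2 mL/min/g to 4.8 mL/min/g.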

Compound 4, intrinsic clearance in a liver preparation (reported as CLH), per the amount of preparation that the assay uses: 3.8 mL/min/g
Compound 4: the middle estimate sits 1.6-fold (0.20 log units) below what was measured; low and high end bracket the measured number.
By their numbers in this assay, from the lowest: compounds 2, 3, 1 and 4 (each within the scatter of the next, the first and the last beyond it).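

In this assay, the exchange of fluoro for bromo on an aromatic carbon of the fused system gives a 1.7-fold higher number from compound 3 to compound 4 (0.24 log units; within the scatter), a step within the scatter, so compound 3 and compound 4 cannot be told apart on clearance. For the compounds shown here, this is the first reading at this position, since the one earlier step exchanged halogens on a different ring: here, a single fluorine and a single bromine on the six-membered aromatic ring of carbon only give clearance numbers that repeat measurements could not separate. No measurement here offers an explanation for this step, and none bears on what either halogen does at this place.

On these data alone, only fluoro and bromo are seen at this position, so it remains open how clearance would read with a group of another kind there, such as an amine, a carboxylic acid or a longer carbon chain. Also open, as far as these compounds go, is whether the same exchange of fluoro for bromo would stay within the scatter on the core of compound 1.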